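The source may report more compounds than this note shows. Statements on the series, on what has been measured and on what is new or still open speak of the compounds shown alone.

Measured so far:
- compound 1 `Cn1c(=O)c(S(=O)(=O)c2ccc(F)cc2[N+](=O)[O-])cc2cnc(Nc3ccc4[nH]ccc4c3)nc21`: 900 nM
- compound 2 `Cn1c(=O)c(S(=O)(=O)c2ccc(F)cc2)cc2cnc(Nc3ccc4[nH]ncc4c3)nc21`: 10000 nM

In a functional assay on K562 cells (Homo sapiens) for inhibition, read by trypan blue exclusion, with a stated time of 72 h (on this read-out higher numbers stand for weaker inhibition and lower numbers for stronger inhibition), compound 1 gives 900 nM, the lowest of the two numbers shown; compound 2 gives 10000 nM, a gap beyond the scatter, but the two structures differ in more than one place, so the values alone are all that can be said. Compound 3 `COc1ccc(S(=O)(=O)c2cc3cnc(Nc4ccc5[nH]ccc5c4)nc3n(C)c2=O)cc1` keeps the core of compound 1 and differs by one change: 4-methoxyphenyl in place of 4-fluoro-2-nitrophenyl on a sulfonyl sulfur. Going by the values given here, no measured pair isolates this change, so the expected step from compound 1 to compound 3 is uncertain; a modest loss of inhibition is expected, a 2.8-fold higher number from compound 1 to compound 3 (0.44 log units; beyond the scatter). For compound 3 the estimate is 2500 nM, within 700 nM to 9000 nM.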

Compound 3, half-maximal inhibitory concentration: 300 nM
Compound 3: middle estimate off by 8.3-fold (0.92 log units), on the high side, outside the stated range (below it).
By their numbers in this assay, from the lowest: compound 3; then compound 1; then compound 2.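

In this assay, the group on a sulfonyl sulfur clearly affects inhibition, with a 3.0-fold lower number from compound 1 to compound 3 (0.48 log units; beyond the scatter) while the shared core stays unchanged. The result also shows that 4-fluoro-2-nitrophenyl is not required at this position, since 4-methoxyphenyl gives stronger inhibition. The data offer no measured explanation for this gain.

The swap removes the nitro and fluoro groups and adds the methoxy group in a single step, leaving their separate contributions unresolved. As far as these compounds go, how an amine or a carboxylic acid in place of the methoxy group would behave also remains open.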